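Swapping the Ester Tail: Expected Microsomal Half-Life

The source may report more compounds than this note shows. Statements on the series, on what has been measured and on what is new or still open speak of the compounds shown alone.

Measured so far in an ADME assay (liver) for pharmacokinetics, with Liver microsome (Homo sapiens) as the target, using microsomes; on this read-out lower numbers stand for a shorter-lived compound and higher numbers for a longer-lived compound:
Compound 1 `CCCOC(=O)/C=C/c1ccc(NC(=O)C2(NC(=O)c3ccc4c(C5CCCC5)c(-c5ncc(Cl)cn5)n(C)c4c3)CCC2)cc1OCC` gives > 5 h, which is a limit of the assay rather than a number.
Compound 2 `CCOc1cc(NC(=O)C2(NC(=O)c3ccc4c(C5CCCC5)c(-c5ncc(Cl)cn5)n(C)c4c3)CCC2)ccc1/C=C/C(=O)OCC(Cl)(Cl)Cl` gives > 5 h, again a limit of the assay.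
Compound 3 `CCOc1cc(NC(=O)C2(NC(=O)c3ccc4c(C5CCCC5)c(-c5ncc(Cl)cn5)n(C)c4c3)CCC2)ccc1/C=C/C(=O)OCCOCCOC` gives 0.85 h.

Among the compounds with values here, compound 3 thus stands alone as the only actual number among the three, the other two results sitting at the limit of > 5 h in this assay, at which 2 of the 3 values shown sit. Compound 4 `CCOc1cc(NC(=O)C2(NC(=O)c3ccc4c(C5CCCC5)c(-c5ncc(Cl)cn5)n(C)c4c3)CCC2)ccc1/C=C/C(=O)OCC(=O)N(C)C(C)C` differs from compound 3 in a single place: isopropyl(methyl)carbamoyl in place of (2-methoxyethoxy)methyl on a saturated chain carbon bound to an oxygen next to a carbonyl group. Within the data shown here, two measured steps bear on this change, both leading into compound 3: an at least 5.8-fold lower number from compound 1 to compound 3 (0.76 log units; beyond the scatter) and an at least 5.8-fold lower number from compound 2 to compound 3 (0.76 log units; beyond the scatter). Both show that the two compounds lacking the 2-methoxyethoxy tail sit at the limit, while compound 3 with that tail is far shorter-lived. Among the measured compounds shown here, removing the tail may therefore lift the number again, but the isopropyl(methyl)carbamoyl group has no measured counterpart here, so the size is uncertain. The expected step is a modest rise, a 2.4-fold higher number from compound 3 to compound 4 (0.37 log units; beyond the scatter). Compound 4 is estimated to give about 2 h in this assay, with a likely range from 0.6 h to 6 h.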

Compound 4, half-life: 0.65 h
Compound 4: the middle estimate sits 3.1-fold (0.49 log units) above what was measured; the range from low to high includes it.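

In this assay there is a 1.3-fold lower number from compound 3 to compound 4 (0.12 log units; within the scatter), so two quite different groups, on a saturated chain carbon bound to an oxygen next to a carbonyl group, cannot be told apart, and the short half-life is not tied to the (2-methoxyethoxy)methyl group alone. The ethyl and trichloromethyl groups at this place stand well apart from the new group, with an at least 7.6-fold lower number from compound 1 to compound 4 (0.88 log units; beyond the scatter) and an at least 7.6-fold lower number from compound 2 to compound 4 (0.88 log units; beyond the scatter). Both of these steps give only a minimum size: the limit of > 5 h in this assay, at which 2 of the 4 values shown sit.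

The compounds shown do not tell which feature the two short-lived tails share that separates them from the two long-lived ones. Going by these compounds, it remains open whether a smaller dimethylcarbamoyl group or a methoxymethyl group at this place would stay with compound 3 and compound 4 or reach the limit.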